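The source may hold more compounds than are shown below. What is called first, only, known or untested is meant among the compounds shown, and "the series" means these compounds.

Measured compounds:
Compound 1 `CC1(C)C(=O)N(c2ccc(Cl)cc2)c2ncccc21`: 13%
Compound 2 `CC1(C)C(=O)N(c2ccccc2)c2ncccc21`: 0%

For the measured compounds named here, in a functional assay on the whole organism with Rattus norvegicus as the target, at a dose of 25 mg/kg (on this read-out higher numbers stand for more inhibition at the one dose given (going by the name of the read-out) and lower numbers for less inhibition), compound 1 gives 13% and compound 2 gives 0%, so compound 2 stands lowest of the two numbers recorded, with compound 1 as its only neighbour. Going by the values given here, the one step between the measured pair is a number 13 percentage points lower from compound 1 to compound 2 (beyond the scatter); it is the sole step bearing on the question at hand.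

Compound 3 `CC1(C)C(=O)N(c2cccc(Cl)c2)c2ncccc21` is not yet measured. Its change from compound 2 is chloro in place of hydrogen on an aromatic carbon. This is the reverse of the measured step in kind, though the chloro now sits meta to a large group rather than where it stands in compound 1, so the step recorded for compound 1 against compound 2 carries over only loosely. On that basis the expected step is a number 10 percentage points higher from compound 2 to compound 3 (within the scatter), a modest rise.

The estimate for compound 3 in this assay is 10%, with a range of 0% to 25%.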

Compound 3, a percentage reported as inhibition, in the whole organism at one dose (the size of the read-out at that dose, not a potency): 0%
Beside the measured number, compound 3's estimate is 10 percentage points above it, within the range that was stated.
By their numbers in this assay, from the lowest: compounds 2 and 3 (each within the scatter of the next); then compound 1.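

In this assay, chloro in place of hydrogen on an aromatic carbon, meta to a large group, gives no change at the digits printed from compound 2 to compound 3 (within the scatter). The presence of a chloro on this aromatic ring is therefore not enough on its own to give a measurable read-out at this place: compound 3 gives 0%, while compound 1, which carries its chloro at another place on the ring, gives 13%. No evidence is at hand to account for these numbers.

Still open, from the compounds shown here alone, is whether a group other than chloro at this same place, such as methoxy, an amine or a carboxylic acid, would give a number different from that of compound 2. Also open, going by these compounds, is how the read-out responds when a longer chain replaces the methyl groups on the shared core.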